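Ethyl in place of acetyl on the amine of compound 2

The source may report more compounds than this note shows. Statements on the series, on what has been measured and on what is new or still open speak of the compounds shown alone.

Two compounds of this series have been run in a functional assay on the whole organism with Canis familiaris (Canis lupus familiaris) as the target, at a dose of 5 mg/kg by the intravenous route; on this read-out higher numbers stand for a stronger effect at the one dose given and lower numbers for a weaker effect. Compound 1 `Cc1nc2c(COc3ccccc3)cccn2c1N` gives 34% in this assay. Compound 2 `CC(=O)Nc1c(C)nc2c(CCc3ccccc3)cccn12` gives 3% in this assay, the lower of the two numbers, a gap to compound 1 that lies beyond the scatter. Among the compounds with values here, the two structures differ in more than one place, so no single step connects them.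

Compound 3 `CCNc1c(C)nc2c(CCc3ccccc3)cccn12` is not yet measured. It differs from compound 2 by ethyl in place of acetyl on a nitrogen on an aromatic ring. In this assay the ring nitrogen of compound 1 carries hydrogen and the nitrogen of compound 2 carries the acetyl, and compound 3 sits between those cases. The step from compound 2 to compound 3 is expected to be upward, of a size that may or may not clear the scatter: a number 12 percentage points higher from compound 2 to compound 3 (beyond the scatter). Compound 3 is expected to give 15% in this assay, within 0% to 38%.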

Compound 3, a percentage reported as inhibition, in the whole organism at one dose (the size of the read-out at that dose, not a potency): 11%
Compound 3: the middle estimate sits 4 percentage points above what was measured; the measured number falls inside the stated range.
By their numbers in this assay, from the lowest: compounds 2 and 3 (each within the scatter of the next); then compound 1.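

In this assay, within the data shown here, the first single-place step reads a number 8 percentage points higher from compound 2 to compound 3 (within the scatter), so acetyl and ethyl on this nitrogen on an aromatic ring cannot be told apart on this read-out. The carbonyl and the hydrogen-bond acceptor counted on acetyl are absent from ethyl, yet the two compounds remain within the scatter of each other at the one dose given. No measurement at hand bears on the reason for this result.

Compound 1 differs from compound 2 and compound 3 in more than one place, so its higher number cannot be assigned to the group on this nitrogen alone. Still open, going by these compounds, is how a free amine, a longer chain such as butyl, or a sulfonamide on this nitrogen would read on the core of compound 2.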